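Nitro in Place of Hydrogen on the Phenyl Ring

This account rests on a few compounds, and the source may have more. Where it says the series, first, only, none or still open, it means among the compounds named here.

Measured compounds:
compound 1, `Cc1cc(-c2cccs2)cn2c(CSCCc3ccccc3)cnc12`, 32 ug/mL
compound 2, `Cc1cc(-c2ccccc2)cn2c(CSCCc3ccccc3)cnc12`, 31 ug/mL

In an ADME assay on HEL cells (Homo sapiens) for cytotoxicity, with a stated time of 3 days (a lower number here means that less compound is tolerated, a higher number that more compound is tolerated), compound 1 gives 32 ug/mL and compound 2 gives 31 ug/mL; the step of a 1.0-fold lower number from compound 1 to compound 2 (0.01 log units; within the scatter) is within the scatter, so compound 2 sits alongside compound 1 in this assay. Compound 3, `Cc1cc(-c2cccc([N+](=O)[O-])c2)cn2c(CSCCc3ccccc3)cnc12`, carries the change (nitro in place of hydrogen on an aromatic carbon). Going by the values given here, no measured step concerns this place: the only step, a 1.0-fold lower number from compound 1 to compound 2 (0.01 log units; within the scatter), alters a different group. Compound 3 is therefore expected to give 30 ug/mL, between 15 ug/mL and 60 ug/mL, an expected 1.0-fold lower number from compound 2 to compound 3 (0.01 log units; within the scatter).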

Compound 3, half-maximal cytotoxic concentration: 43 ug/mL
Beside the measured number, compound 3's estimate is 1.4-fold (0.16 log units) below it; low and high end bracket the measured number.
By their numbers in this assay, from the lowest: compounds 2, 1 and 3 (each within the scatter of the next).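

In this assay the step of a 1.4-fold higher number from compound 2 to compound 3 (0.14 log units; within the scatter) is within the scatter, so nitro in place of hydrogen on this aromatic carbon, meta to a large group, leaves the tolerated concentration unresolved from that of the unsubstituted phenyl. The step of a 1.3-fold higher number from compound 1 to compound 3 (0.13 log units; within the scatter) is also within the scatter, which places 3-nitrophenyl alongside thiophen-2-yl as well. No evidence bears on why this change leaves the number unmoved. From the compounds shown here alone, whether an amine or a carboxylic acid on this carbon would move the number beyond the scatter remains open.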